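Cyclohexylsulfanyl for Methylpiperidinyl on Two Related Cores

The source may hold more compounds than are shown below. What is called first, only, known or untested is meant among the compounds shown, and "the series" means these compounds.

Compound 1 `Cc1ccc(C(C(=O)NCc2ccc(C(F)(F)F)nc2N2CCC(C)CC2)c2ccc(NS(C)(=O)=O)c(F)c2)cc1` and compound 2 `Cc1ccc(C(C(=O)NCc2ccc(C(F)(F)F)nc2SC2CCCCC2)c2ccc(NS(C)(=O)=O)c(F)c2)cc1` share one core. In an assay on CHO cells for antagonist activity at transient receptor potential cation channel subfamily V member 1 (Homo sapiens), read by FLIPR (on this read-out lower numbers stand for stronger inhibition and higher numbers for weaker inhibition), compound 1 gives 1.1 nM, and compound 2 gives 7.5 nM. The two differ by cyclohexylsulfanyl in place of 4-methylpiperidin-1-yl on an aromatic carbon, and this change gave a 6.8-fold higher number from compound 1 to compound 2 (0.83 log units; beyond the scatter). Compound 3 `CC1CCN(c2nc(C(F)(F)F)ccc2CNC(=O)C(C)(C)c2ccc(NS(C)(=O)=O)c(F)c2)CC1` is built on a second core; the difference between the two cores is not broken down here. In this assay compound 3 gives 49 nM, the highest number among the three measured compounds. Compound 4 `CC(C)(C(=O)NCc1ccc(C(F)(F)F)nc1SC1CCCCC1)c1ccc(NS(C)(=O)=O)c(F)c1` carries the same change on the core of compound 3, (cyclohexylsulfanyl in place of 4-methylpiperidin-1-yl on an aromatic carbon). The earlier step of a 6.8-fold higher number from compound 1 to compound 2 (0.83 log units; beyond the scatter) was modest but beyond the scatter, so a step of similar size is expected for the same change on the second core. The expected step is a 6.7-fold higher number from compound 3 to compound 4 (0.83 log units; beyond the scatter). Compound 4 is therefore estimated at 330 nM, with a likely range from 110 nM to 1000 nM.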

Compound 4, inhibition constant: 65.7 nM
Compound 4: middle estimate off by 5.0-fold (0.70 log units), on the high side; measured number below the stated range.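

Cyclohexylsulfanyl in place of 4-methylpiperidin-1-yl on the second core gave a 1.3-fold higher number from compound 3 to compound 4 (0.13 log units; within the scatter) in this assay. The size of the step therefore did not carry over from one core to the other: the same change on two cores in this assay, a 6.8-fold higher number (0.83 log units; beyond the scatter) from compound 1 to compound 2 and a 1.3-fold higher number (0.13 log units; within the scatter) from compound 3 to compound 4, 5.1-fold (0.71 log units) apart, beyond the scatter of two such steps. This shows that, for these two pairs, the effect of the change depends on the core, but it does not show which structural difference between the cores is responsible or how the change would behave on any further core.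

The compounds shown leave open whether a cyclohexyloxy group or a morpholine ring on the same aromatic carbon would also give steps that differ between the two cores.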